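Swapping fluoro for trifluoromethyl on the aryl amide

A few compounds are considered here, and "the series" means these few. Any claim that something is new, unique, unknown or untested is made for them only; others in the source may bear on it.

Compound 1 `CN(C)C(=O)c1cc2cnc(Nc3ccc(NC(=O)C4(C(=O)Nc5ccc(F)cc5)CC4)cc3)nc2n1C1CCCC1` is the strongest of the three measured compounds in a functional assay on A549 cells (Homo sapiens) for inhibition, read by CCK-8 assay, with a stated time of 72 h, tested at 1 uM (on this read-out lower numbers stand for less inhibition of growth and higher numbers for more inhibition of growth at the one concentration tested), where compound 1 gives 86.6%. Its two neighbours carry a different halogen in a different place: compound 2 `CN(C)C(=O)c1cc2cnc(Nc3ccc(NC(=O)C4(C(=O)Nc5cccc(Cl)c5)CC4)cc3)nc2n1C1CCCC1` gives 8.3%, and compound 3 `CN(C)C(=O)c1cc2cnc(Nc3ccc(NC(=O)C4(C(=O)Nc5cccc(Br)c5)CC4)cc3)nc2n1C1CCCC1` gives 20.2%. The steps away from compound 1 are large: a number 78.3 percentage points lower from compound 1 to compound 2 (beyond the scatter) and a number 66.4 percentage points lower from compound 1 to compound 3 (beyond the scatter). Between the two weaker compounds, where only the halogen changes, the step is small: a number 11.9 percentage points higher from compound 2 to compound 3 (beyond the scatter).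

Compound 4 `CN(C)C(=O)c1cc2cnc(Nc3ccc(NC(=O)C4(C(=O)Nc5ccc(C(F)(F)F)cc5)CC4)cc3)nc2n1C1CCCC1` differs from compound 1 by trifluoromethyl in place of fluoro on an aromatic carbon. Within the data shown here, no measured step changes only the size of the group at this position; the large steps to compound 2 and compound 3 each change both the kind of halogen and its place, so they bear only loosely on the present change. Among the measured compounds shown here, the single step that keeps the place fixed, from compound 2 to compound 3, is modest. A moderate downward step is therefore expected, with wide uncertainty: a number 26.6 percentage points lower from compound 1 to compound 4 (beyond the scatter). For compound 4 the estimated value in this assay is 60%, expected to fall between 20% and 90%.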

Compound 4, percent growth inhibition at one concentration: -25.3%
Estimate against measurement, compound 4: 85.3 percentage points above, outside the stated range (below it).
By their numbers in this assay, from the lowest: compound 4; then compound 2; then compound 3; then compound 1.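

Among these compounds, with the place held fixed, para to a large group, and only fluoro exchanged for trifluoromethyl, this assay gives a number 111.9 percentage points lower from compound 1 to compound 4 (beyond the scatter), so this position is highly sensitive to the group it carries, which the earlier steps could not show because they changed both halogen and place. The 4-(trifluoromethyl)phenyl compound also falls short of both earlier weak compounds, with a number 45.5 percentage points lower from compound 3 to compound 4 (beyond the scatter) and a number 33.6 percentage points lower from compound 2 to compound 4 (beyond the scatter), so a group at this place does not by itself secure a high number, and among these four compounds only the 4-fluorophenyl group gives one. No measurement here accounts for the drop.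

The compounds shown leave open how a chloro, methyl, methoxy or amine group at this same place would read, and so whether the number declines gradually from fluoro or collapses only with trifluoromethyl. A 3-fluorophenyl compound would help separate the effect of place from that of the kind of halogen, a distinction the earlier large steps cannot make.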